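The source may report more compounds than this note shows. Statements on the series, on what has been measured and on what is new or still open speak of the compounds shown alone.

In a functional assay on MCF cells (Homo sapiens) for antiproliferative activity, with a stated time of 72 h (a higher number here means a weaker inhibitor, a lower number a stronger inhibitor), three compounds have been measured so far:

Compound 1 `OC[C@H]1O[C@@H](n2cnc3c(NCc4ccccc4F)ncnc32)[C@H](O)[C@@H]1O`, a limit of the assay: > 166000 nM
Compound 2 `OC[C@H]1O[C@@H](n2cnc3c(NCc4cccc(F)c4)ncnc32)[C@H](O)[C@@H]1O`: 15300 nM
Compound 3 `OC[C@H]1O[C@@H](n2cnc3c(NCc4ccc(F)cc4)ncnc32)[C@H](O)[C@@H]1O`: 21000 nM

Compound 3 lies within the scatter of compound 2, as a 1.4-fold higher number from compound 2 to compound 3 (0.14 log units; within the scatter) shows, and both give real numbers where compound 1 reached only a limit. Compound 4 `OC[C@H]1O[C@@H](n2cnc3c(NCc4ccc(Cl)cc4)ncnc32)[C@H](O)[C@@H]1O` carries chloro in place of fluoro on an aromatic carbon, para to a large group (chloro in place of fluoro on an aromatic carbon). Among the measured compounds shown here, no measured step exchanges one halogen for another, so the evidence is indirect. The two steps beyond the scatter, an at least 10-fold lower number from compound 1 to compound 2 (1.03 log units; beyond the scatter) and an at least 7.9-fold lower number from compound 1 to compound 3 (0.89 log units; beyond the scatter), both leave the 2-fluorophenyl group, whereas compound 4 keeps its halogen where compound 3 has its fluoro. The closest guide is therefore a 1.4-fold higher number from compound 2 to compound 3 (0.14 log units; within the scatter), which stays within the scatter. No step beyond the scatter is expected in this assay. The expected change is a 1.3-fold lower number from compound 3 to compound 4 (0.12 log units; within the scatter). The estimate for compound 4 is 16000 nM, with an expected range from 6000 nM to 45000 nM.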

Compound 4, half-maximal inhibitory concentration: > 166000 nM
Compound 4: no number, only a limit (the forecaster's own chance of this, stated with the estimate: 10%); middle value at least 10-fold (1.01 log units) from the limit.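

In this assay compound 4 gives no number, only a limit of the assay, and compound 1 sits at that same limit: the limit of > 166000 nM in this assay, at which 2 of the 4 values shown sit.

Among the compounds shown here, until now the only steps beyond the scatter left the 2-fluorophenyl group, but here the halogen's place on the ring is held and only its identity changes: chloro in place of fluoro on an aromatic carbon, para to a large group, gives an at least 7.9-fold higher number from compound 3 to compound 4 (0.89 log units; beyond the scatter). The change of both halogen and place gives an at least 10-fold higher number from compound 2 to compound 4 (1.03 log units; beyond the scatter), while the step between the two compounds at the limit cannot be read.

The compounds shown do not say why a single halogen exchange at this place has so large an effect. They also leave open how bromo, methyl or methoxy on the same aromatic carbon would read in this assay.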